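The compounds below may be only part of what the source reports. "The series", "measured", "known", "first", "only" and "open" are said of these compounds alone.

Within the data shown here, compound 1 `CCN(Cc1ccccc1)C(=O)C1CCN(S(=O)(=O)c2ccc(OC)cc2)CC1` is the only member of this set with a numerical result: in a functional assay on CHO cells for positive allosteric modulation of muscarinic acetylcholine receptor M5 (Homo sapiens), read by calcium flux (on this read-out higher numbers stand for larger maximal responses and lower numbers for smaller maximal responses), compound 1 reaches 84%. Compound 2 `CCN(Cc1ccccc1)C(=O)C1CCN(S(=O)(=O)c2ccccc2OC)CC1` carries "not determined" (no result reported) in this assay, and compound 3 `CCN(Cc1ccccc1)C(=O)C1CCN(S(=O)(=O)c2c[nH]cn2)CC1` likewise stands with "not determined" (no result reported) there, so nothing places it above or below compound 1. Compound 4 `CCN(Cc1ccccc1)C(=O)C1CCN(S(=O)(=O)c2ccc(C)s2)CC1` has not yet been measured. Compound 4 differs from compound 3 by 5-methylthiophen-2-yl in place of 1H-imidazol-4-yl on a sulfonyl sulfur. Among the measured compounds shown here, with no step between measured compounds available, the size and direction of this change in this assay cannot be read from the data, and a shift beyond the scatter in either direction is possible. Taking compound 1 as the only anchor, compound 4 is expected to reach about 75%, likely between 45% and 100%.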

Compound 4, largest response reached (reported as percent of maximum), in percent of the reference or control that the assay uses: 64%
The estimate for compound 4 lay 11 percentage points above the measured number; the range from low to high includes it.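

Among these compounds, at the sulfonyl sulfur, the change to 5-methylthiophen-2-yl from 4-methoxyphenyl gives a number 20 percentage points lower from compound 1 to compound 4 (beyond the scatter) in this assay, the first evidence that the response depends on the group carried there. It also shows that a five-membered aromatic ring at this place retains a measurable response, while the step from compound 3 cannot be read. Nothing measured explains the lower response. On these data alone, whether an unsubstituted thiophen-2-yl, a phenyl or a cyclopropyl group would stand nearer compound 1 or compound 4 remains open.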